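The source may report more compounds than this note shows. Statements on the series, on what has been measured and on what is new or still open speak of the compounds shown alone.

Of the compounds shown here, three built on one shared core have been tested in a functional assay on HCT-116 cells (Homo sapiens) for cytotoxicity, read by MTT assay, with a stated time of 72 h; a higher number here means a weaker inhibitor, a lower number a stronger inhibitor. Compound 1 `NCCNc1c(C(=O)NCc2ccc(F)cc2)nc(Br)c2cccnc12` carries a 2-aminoethyl group on a ring nitrogen; in this assay compound 1 gives only a limit, > 20000 nM. Compound 2 `C[C@H](Nc1c(C(=O)NCc2ccc(F)cc2)nc(Br)c2cccnc12)c1ccccc1` bears a 1-phenylethyl group on that nitrogen, and in this assay compound 2 likewise returns only the limit of > 20000 nM. Going by the values given here, compound 3 `NCCCCCCNc1c(C(=O)NCc2ccc(F)cc2)nc(Br)c2cccnc12` carries a 6-aminohexyl group, and in this assay compound 3 gives 7000 nM, the only true number among the three. The step of an at least 2.8-fold lower number from compound 1 to compound 3 (0.45 log units; beyond the scatter) and the step of an at least 2.8-fold lower number from compound 2 to compound 3 (0.45 log units; beyond the scatter) are each at least modest, though both rest on the limit (the limit of > 20000 nM in this assay, at which 2 of the 3 values shown sit). The step that the two limits leave unreadable from compound 1 to compound 2 cannot be read.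

Compound 4 `O=C(NCc1ccc(F)cc1)c1nc(Br)c2cccnc2c1NCc1ccc(F)cc1` differs from compound 3 by 4-fluorophenyl in place of 5-aminopentyl on a saturated chain carbon bound to a nitrogen on an aromatic ring. Exchanging the 5-aminopentyl for a 4-fluorophenyl runs against the direction of the step of an at least 2.8-fold lower number from compound 2 to compound 3 (0.45 log units; beyond the scatter). Compound 2, which also carries an aromatic ring on that nitrogen, stands at a limit. Compound 4 is therefore expected to show a higher number, a step of about a 3.6-fold higher number from compound 3 to compound 4 (0.55 log units; beyond the scatter), quite possibly reaching the limit again. The estimate for compound 4 in this assay is 25000 nM, between 8000 nM and 80000 nM.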

Compound 4, half-maximal inhibitory concentration: > 20000 nM
Compound 4: no number, only a limit; the forecaster's own chance of this, stated with the estimate: 65%; the middle value does not contradict the limit.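

In this assay, the step of an at least 2.8-fold higher number from compound 3 to compound 4 (0.45 log units; beyond the scatter) shows that a 4-fluorobenzyl group on this nitrogen, in place of the 6-aminohexyl group, also falls short of compound 3, so two different aromatic groups now do. Compound 4 gives only a limit, and the steps that join it to the other two limit values cannot be read: the limit of > 20000 nM in this assay, at which 3 of the 4 values shown sit.

Among these four compounds only the 6-aminohexyl group gives a number, and compound 1 goes against any reading that an amine-bearing chain alone is enough.

The change to compound 4 takes away the amine and the chain together, and the compounds shown leave open which of the two counts. A plain hexyl chain with no amine, or a longer chain such as 8-aminooctyl, would pull the two apart.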